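The source may hold more compounds than are shown below. What is called first, only, known or untested is meant among the compounds shown, and "the series" means these compounds.

Among the compounds with values here, in a functional assay on HeLa cells (Homo sapiens) for antiproliferative activity, read by sulforhodamine B assay, with a stated time of 48 h (a lower number here means a stronger inhibitor, a higher number a weaker inhibitor), two compounds have numbers so far. Compound 1 (`COc1cc(OC)c2sc(-c3ccc(N/C=C\C(=O)c4cc(OC)c(OC)c(OC)c4)cc3)nc2c1`) gives 17800 nM and compound 2 (`COc1cc(C(=O)/C=C\Nc2ccc(-c3nc4cc(OC)c(OC)c(OC)c4s3)cc2)cc([N+](=O)[O-])c1OC`) gives 7800 nM as the lower of the two. That makes compound 2 the stronger inhibitor of this pair, and the gap lies beyond the usual scatter of repeated measurements. Compound 3 (`COc1cc(OC)c2sc(-c3ccc(N/C=C\C(=O)c4cc(OC)c(OC)c([N+](=O)[O-])c4)cc3)nc2c1`) differs from compound 2 by having hydrogen in place of methoxy on an aromatic carbon of the core. Within the data shown here, no measured pair shows this change alone, so only a modest move can be expected. In this assay the expected shift is small and toward a weaker number, probably within the scatter, and a 1.3-fold higher number from compound 2 to compound 3 (0.11 log units; within the scatter) is the estimated step. Compound 3 is therefore expected near 10000 nM with an estimated range from 4000 nM to 25000 nM for its measurement.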

Compound 3, half-maximal inhibitory concentration: 19000 nM
The estimate for compound 3 lay 1.9-fold (0.28 log units) below the measured number, and the stated range covers the measured number.
By their numbers in this assay, from the lowest: compound 2; then compounds 1 and 3 (each within the scatter of the next).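

In this assay, hydrogen in place of methoxy on an aromatic carbon of the core gives a 2.4-fold higher number from compound 2 to compound 3 (0.39 log units; beyond the scatter), so in this pair the methoxy at this position goes with the stronger number. Elsewhere in the molecule, nitro in place of methoxy on an aromatic carbon gives a 1.1-fold higher number from compound 1 to compound 3 (0.03 log units; within the scatter), which means that this change shows no real effect on the core of compound 3. Nothing measured here explains either result.

Going by these compounds, it remains open whether methoxy itself matters at that core carbon or whether other groups, such as an amine or a chlorine atom, would serve equally well. On these data alone, it is also open whether nitro and methoxy would still match on the core of compound 2, which carries the additional methoxy.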